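The source may report more compounds than this note shows. Statements on the series, on what has been measured and on what is new or still open speak of the compounds shown alone.

In an assay on CHO cells for displacement of a labelled ligand from adenosine receptor A3 (Homo sapiens), read by scintillation counting, tested at 10 uM (on this read-out higher numbers stand for more inhibition at the one concentration tested (going by the name of the read-out) and lower numbers for less inhibition), compound 1 `CC(C)(C)Cc1c(Br)sc(N)c1C(=O)c1cccc(Cl)c1` gives 1%, compound 2 `CC(C)(C)Cc1c(-c2ccccc2)sc(N)c1C(=O)c1ccc(Cl)cc1` gives 1%, and compound 3 `CC(C)(C)Cc1c(-c2ccccc2)sc(N)c1C(=O)c1cccc(Cl)c1` gives 5%. Compound 3 thus carries the top number of the three, but the gaps to the other two are small: a number 4 percentage points higher from compound 1 to compound 3 (within the scatter) and a number 4 percentage points higher from compound 2 to compound 3 (within the scatter), both inside the ordinary scatter of repeated measurements, so the three compounds cannot be told apart on these numbers. Compound 4 `CC(C)(C)Cc1c(-c2ccccc2)sc(N)c1C(=O)c1ccccc1Cl` has not yet been measured. It differs from compound 3 in one place: 2-chlorophenyl in place of 3-chlorophenyl on a carbonyl carbon. For the measured compounds named here, only one measured step involves the same kind of change, a different chlorophenyl on the carbonyl carbon, and that step, a number 4 percentage points higher from compound 2 to compound 3 (within the scatter), stayed within the scatter. Nothing in the shown numbers hints that 2-chlorophenyl in place of 3-chlorophenyl should act differently, so the expected step in this assay is a number 2 percentage points lower from compound 3 to compound 4 (within the scatter), no larger than the scatter. Compound 4 is therefore estimated to give 3% in this assay, within a range from 0% to 12%.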

Compound 4, a percentage reported as inhibition, at one concentration (the size of the read-out at that concentration, not a potency): 1%
Compound 4: middle estimate off by 2 percentage points, on the high side; low and high end bracket the measured number.
By their numbers in this assay, from the lowest: compounds 1, 2, 4 and 3 (each within the scatter of the next).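

With compound 4, all three chlorophenyl groups on the carbonyl carbon have been read on the same core in this assay. Putting 2-chlorophenyl in place of 3-chlorophenyl gives a number 4 percentage points lower from compound 3 to compound 4 (within the scatter) and putting it in place of 4-chlorophenyl gives no change at the digits printed from compound 2 to compound 4 (within the scatter) in this series, so moving the chlorine around this ring produces no difference that can be told from the scatter, and the three compounds remain indistinguishable on these numbers. No measurement is at hand that would explain this result. Still open, from the compounds shown here alone, is whether a different group on the carbonyl carbon, such as an unsubstituted phenyl, a methoxyphenyl or a pyridyl, would move the number beyond the scatter. Also open, going by these compounds, is whether the three chlorophenyl groups would separate on a related compound with a much higher number.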